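Methyl to bromo swap in the series

The source may report more compounds than this note shows. Statements on the series, on what has been measured and on what is new or still open speak of the compounds shown alone.

Measured in an ADME assay on HaCaT cells (Homo sapiens) for inhibition, read by sulforhodamine B assay, with a stated time of 48 h (a higher number here means a weaker inhibitor of growth, a lower number a stronger inhibitor of growth), so far:
- Compound 1 `S=C(N/N=C/c1cccs1)Nc1ccccc1` gives > 100000 nM as a limit of the assay
- Compound 2 `S=C(N/N=C/c1cccs1)Nc1cccnc1` gives 45400 nM as a number
- Compound 3 `Cc1ccc(NC(=S)N/N=C/c2cccs2)cc1` gives 17600 nM as a number

Compound 3 holds the lowest number of the two true numbers, and compound 2 sits nearest at 45400 nM on this scale, a gap beyond the scatter. The change bromo in place of methyl on an aromatic carbon puts bromo in place of methyl on an aromatic carbon, para to a large group, and gives compound 4 `S=C(N/N=C/c1cccs1)Nc1ccc(Br)cc1` as the next member. Among the compounds with values here, one measured step bears on it, methyl in place of hydrogen on an aromatic carbon. Within the data shown here, with an at least 5.6-fold lower number from compound 1 to compound 3 (0.75 log units; beyond the scatter) as the sole guide and no measured step that replaces methyl itself, only a small move in this assay is expected, slightly downward if anything and perhaps none beyond the scatter. The estimated step is a 1.2-fold lower number from compound 3 to compound 4 (0.07 log units; within the scatter) on this reading. Compound 4 is estimated at 15000 nM within a range from 6000 nM to 40000 nM for now.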

Compound 4, concentration for 50% growth inhibition: 800 nM
For compound 4 the middle estimate is 19-fold (1.27 log units) above the measured one; measured number outside the range, below it.
By their numbers in this assay, from the lowest: compound 4; then compound 3; then compound 2. At a limit, above all of these: compound 1.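

In this assay the aromatic carbon para to a large group proves far more sensitive to the choice of group than the methyl step alone could show, with a 22-fold lower number from compound 3 to compound 4 (1.34 log units; beyond the scatter) for the exchange of one heavy atom for another. Methyl therefore does not mark the end of what this place allows, and the order of the numbers now puts bromo ahead of methyl and hydrogen. Bromo in place of hydrogen gives an at least 120-fold lower number from compound 1 to compound 4 (2.09 log units; beyond the scatter) as its step, and this size is only a bound since compound 1 stands at a limit and not at a number: the limit of > 100000 nM in this assay, at which 1 of the 4 values shown sits.

Open, as far as these compounds go, is whether the large drop belongs to bromo alone or extends to other groups at this place, such as chloro, methoxy, an amine or a carboxylic acid. Also open, from the compounds shown here alone, is whether bromo brings a similar step on the core of compound 2.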